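Series notes: trifluoromethyl in place of methoxy

A few compounds are considered here, and "the series" means these few. Any claim that something is new, unique, unknown or untested is made for them only; others in the source may bear on it.

Measured compounds:
compound 1 `COc1ccc(-c2nc(C(=O)/C=C\Nc3ccc4[nH]ccc4c3)c3ccccn23)cc1` gives 13000 nM
compound 2 `COc1ccc(N/C=C\C(=O)c2nc(-c3ccc(C(F)(F)F)cc3)n3ccccc23)cc1OC` gives a limit, > 30000 nM
compound 3 `COc1ccc(-c2nc(C(=O)/C=C\Nc3ccc(Cl)cc3)c3ccccn23)cc1` gives 37300 nM

In a functional assay on BT-474 cells (Homo sapiens) for cytotoxicity, read by MTT assay, with a stated time of 48 h (on this read-out higher numbers stand for weaker inhibition and lower numbers for stronger inhibition), compound 3 stands highest of the two numbers reported. Going by the values given here, its nearest neighbour is compound 1, and the single measured step, a 2.9-fold higher number from compound 1 to compound 3 (0.46 log units; beyond the scatter), separates them. For compound 2 the read-out is a limit only, > 30000 nM, and it sits at the limit of > 30000 nM in this assay, at which 1 of the 3 values shown sits. Among the compounds with values here, compound 2 carries a trifluoromethyl group on the aryl attached to the shared core, as compound 4 does, but it is not a one-place neighbour of any other compound, so no step to it can be read.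

Compound 4 `O=C(/C=C\Nc1ccc(Cl)cc1)c1nc(-c2ccc(C(F)(F)F)cc2)n2ccccc12` is compound 3 with trifluoromethyl in place of methoxy on an aromatic carbon. Within the data shown here, none of the measured steps carries this change; the only measured step concerns the group on the amine nitrogen, not the aryl on the core. Among the measured compounds shown here, what the numbers show is that compound 3 is already the weakest measured number and the one compound bearing the incoming trifluoromethylphenyl reported only a limit. The step is therefore expected to be a 1.2-fold higher number from compound 3 to compound 4 (0.08 log units; within the scatter), toward a higher number, with a real chance that only a limit is returned. Compound 4 is estimated at 45000 nM, between 15000 nM and 120000 nM.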

Compound 4, half-maximal inhibitory concentration: 3820 nM
Estimate against measurement, compound 4: 12-fold (1.07 log units) above, outside the stated range (below it).
By their numbers in this assay, from the lowest: compound 4; then compound 1; then compound 3.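

In this assay, trifluoromethyl in place of methoxy on an aromatic carbon, para to a large group, with 4-chlorophenyl kept on the amine nitrogen, gives a 9.8-fold lower number from compound 3 to compound 4 (0.99 log units; beyond the scatter) and moves the read-out toward stronger inhibition. Going by these compounds alone, this is the first one-place reading at this position, and it shows that the read-out responds to the group there, whereas the earlier step spoke only to the amine nitrogen. Compound 2 is reported as a limit only: the limit of > 30000 nM in this assay, at which 1 of the 4 values shown sits. With 4-(trifluoromethyl)phenyl held on the core, 4-chlorophenyl in place of 3,4-dimethoxyphenyl on the amine nitrogen gives an at least 7.8-fold lower number from compound 2 to compound 4 (0.89 log units; beyond the scatter) as a bound rather than a measured size, so the amine nitrogen group still counts with this aryl in place.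

On these data alone, the methoxy to trifluoromethyl change is read on a single pair, so whether it carries over with 1H-indol-5-yl on the amine nitrogen stays open. Also open, as far as these compounds go, is how a nitrile or a plain hydrogen at the same aromatic carbon would read against trifluoromethyl and methoxy.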